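The compounds below may be only part of what the source reports. "The series", "measured", "known", "first", "only" and "open" are said of these compounds alone.

Compound 1 `Cc1nnc(-c2ccc(N3CCC(Oc4ccccc4C(F)(F)F)CC3)nn2)s1` gives 2.3 nM in an assay on microsomes from liver for inhibition of acyl-CoA desaturase 1 (Rattus norvegicus) (a higher number here means a weaker inhibitor, a lower number a stronger inhibitor), and compound 2 `Brc1ccccc1OC1CCN(c2ccc(-n3ccnc3)nn2)CC1` gives 5 nM in this assay. Of these two numbers compound 1 holds the lower one; compound 2 sits at a higher number, a gap beyond the scatter. Compound 3 `OCc1nnc(-c2ccc(N3CCC(Oc4ccccc4C(F)(F)F)CC3)nn2)o1` is not yet measured. It differs from compound 1 in one place: 5-(hydroxymethyl)-1,3,4-oxadiazol-2-yl in place of 5-methyl-1,3,4-thiadiazol-2-yl on an aromatic carbon. Among the compounds with values here, no measured pair covers this change, so the size of the step in this assay is open; a modest rise in the number is expected, a 2.2-fold higher number from compound 1 to compound 3 (0.34 log units; beyond the scatter). For compound 3 the estimate in this assay is 5 nM, with a range from 1.5 nM to 17 nM.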

Compound 3, half-maximal inhibitory concentration: 2.9 nM
Compound 3: middle estimate off by 1.7-fold (0.24 log units), on the high side; the measured number falls inside the stated range.
By their numbers in this assay, from the lowest: compounds 1, 3 and 2 (each within the scatter of the next, the first and the last beyond it).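

In this assay, 5-(hydroxymethyl)-1,3,4-oxadiazol-2-yl in place of 5-methyl-1,3,4-thiadiazol-2-yl gives a 1.3-fold higher number from compound 1 to compound 3 (0.10 log units; within the scatter), so the two groups cannot be told apart at this position. This position therefore carries a hydrogen-bond donor on the hydroxymethyl group, absent from the leaving group, without a readable difference in the number. No supporting data bear on this result.

Ring and side chain change together here, so 5-methyl-1,3,4-oxadiazol-2-yl would be needed to separate them. As far as these compounds go, a carboxylic acid or an amine on the oxadiazole ring also remains open.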